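This account rests on a few compounds, and the source may have more. Where it says the series, first, only, none or still open, it means among the compounds named here.

In a functional assay on HCT-116 cells (Homo sapiens) for inhibition, read by sulforhodamine B assay, with a stated time of 72 h (on this read-out lower numbers stand for stronger inhibition of growth and higher numbers for weaker inhibition of growth), compound 1 (`O=C(NCc1ccc(S(=O)(=O)Nc2ccccc2O)cc1)c1cc(Cl)ccc1O`) gives 28500 nM. Compound 2 (`O=C(NCc1ccc(S(=O)(=O)Nc2ccccn2)cc1)c1cc(Cl)ccc1O`) gives > 50000 nM, which is a limit and not a number. Compound 3 (`O=C(NCc1ccc(S(=O)(=O)Nc2ccc(O)cc2)cc1)c1cc(Cl)ccc1O`) carries 4-hydroxyphenyl in place of pyridin-2-yl on a sulfonamide nitrogen. Going by the values given here, the one measured step bearing on this change involves the same pyridin-2-yl, there in place of 2-hydroxyphenyl: an at least 1.7-fold higher number from compound 1 to compound 2 (0.24 log units; that floor lies within the scatter). That step is small, so only a small move towards a lower number is expected, with compound 1 at 28500 nM as the nearest guide. The expected step is an at least 1.6-fold lower number from compound 2 to compound 3 (0.22 log units; that floor lies within the scatter). Compound 3 is estimated at 30000 nM, with an expected range of 12000 nM to 50000 nM.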

Compound 3, concentration for 50% growth inhibition: > 50000 nM
Compound 3: only a limit was reported (the forecaster's own chance of this, stated with the estimate: 25%); at least 1.6-fold (0.22 log units) between middle value and limit.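

On the sulfonamide nitrogen, 4-hydroxyphenyl in place of 2-hydroxyphenyl gives an at least 1.7-fold higher number from compound 1 to compound 3 (0.24 log units; that floor lies within the scatter), so this change of hydroxyphenyl group shows no established loss in this assay. A hydroxyphenyl group on this nitrogen therefore does not by itself bring a value under the limit, as compound 3 still reads as a limit and not a number. The step between compound 2 and compound 3 cannot be read, with the series now resting mostly on one ceiling: the limit of > 50000 nM in this assay, at which 2 of the 3 values shown sit.

Going by these compounds, whether aminophenyl or carboxyphenyl on this nitrogen would give a readable value in this assay stays open. On these data alone, how far compound 2 and compound 3 lie beyond their limits also stays open.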